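The source may report more compounds than this note shows. Statements on the series, on what has been measured and on what is new or still open speak of the compounds shown alone.

Measured in an ADME assay on microsomes from liver (Homo sapiens) for metabolic stability, read by HPLC, with a stated time of 60 min, tested at 0.2 mg/mL; a higher number here means faster removal of the compound, a lower number slower removal:

- compound 1 `O=C(NCc1ccc(Cl)cc1Cl)[C@@H]1CCC(=O)N1c1ccsc1`: 762 mL.min-1.g-1
- compound 2 `O=C(NCc1ccc(Cl)cc1Cl)[C@@H]1CCC(=O)N1c1ccco1`: 411 mL.min-1.g-1
- compound 3 `O=C(NCc1ccc(Cl)cc1Cl)[C@@H]1CCC(=O)N1c1nccs1`: 253 mL.min-1.g-1

Compound 3 is clearly separated from only one of the other two compounds. There is a 3.0-fold lower number from compound 1 to compound 3 (0.48 log units; beyond the scatter), whereas a 1.6-fold lower number from compound 2 to compound 3 (0.21 log units; within the scatter) does not separate that pair.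

The next compound is compound 4 `O=C(NCc1ccc(Cl)cc1Cl)[C@@H]1CCC(=O)N1c1cscn1`. The change is 1,3-thiazol-4-yl in place of 1,3-thiazol-2-yl on an amide-type nitrogen in a ring. In words, 1,3-thiazol-4-yl stands in place of 1,3-thiazol-2-yl on an amide-type nitrogen in a ring, so the same atoms are simply joined differently.

Among the compounds with values here, no measured step makes this exact swap. The closest guides are the other ring swaps at the same place: a 1.9-fold lower number from compound 1 to compound 2 (0.27 log units; within the scatter), a 3.0-fold lower number from compound 1 to compound 3 (0.48 log units; beyond the scatter) and a 1.6-fold lower number from compound 2 to compound 3 (0.21 log units; within the scatter). Only one of these goes beyond the scatter, and only modestly, so a large move seems unlikely, although the direction is uncertain. In this assay, the expected change is a 1.4-fold higher number from compound 3 to compound 4 (0.14 log units; within the scatter), a small rise that would stay within the scatter. For compound 4, the estimated value is 350 mL.min-1.g-1, with an expected range of 170 mL.min-1.g-1 to 700 mL.min-1.g-1.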

Compound 4, intrinsic clearance in microsomes: 379 mL.min-1.g-1
Beside the measured number, compound 4's estimate is 1.1-fold (0.03 log units) below it; low and high end bracket the measured number.
By their numbers in this assay, from the lowest: compounds 3, 4, 2 and 1 (each within the scatter of the next, the first and the last beyond it).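

Swapping 1,3-thiazol-2-yl for 1,3-thiazol-4-yl, with the same atoms joined differently, gives a 1.5-fold higher number from compound 3 to compound 4 (0.18 log units; within the scatter) in this assay, so these two thiazole attachments cannot be told apart here. The new compound also stays close to the furan-2-yl compound, with a 1.1-fold lower number from compound 2 to compound 4 (0.04 log units; within the scatter), and even the thiophen-3-yl compound is not clearly separated from it, with a 2.0-fold lower number from compound 1 to compound 4 (0.30 log units; within the scatter), whereas 1,3-thiazol-2-yl did stand apart from thiophen-3-yl, with a 3.0-fold lower number from compound 1 to compound 3 (0.48 log units; beyond the scatter). Nothing measured here explains these numbers.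

All four groups on this amide-type nitrogen are five-membered aromatic rings. Going by these compounds, a six-membered ring such as phenyl or pyridin-3-yl, or an open chain such as a methoxyethyl group, could give a number well away from these four, and that remains open.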